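Notes on the step from compound 2 to compound 3

The source may hold more compounds than are shown below. What is called first, only, known or untested is meant among the compounds shown, and "the series" means these compounds.

In an ADME assay on BJ cells (Homo sapiens) for cytotoxicity, with a stated time of 72 h (on this read-out higher numbers stand for an effect only at larger amounts of compound and lower numbers for an effect already at smaller amounts), compound 2 (`CCOC(=O)/C(C)=C/c1cc(/C=C/[C@](C)(/C=C/c2ccc(OC)cc2)CCC=C(C)C)ccc1O`) gives > 36600 nM as its reading, which is a limit and not a number. Compound 1 (`COc1ccc(/C=C/[C@@](C)(/C=C/c2ccc(O)c(C=O)c2)CCC=C(C)C)cc1`) gives 9800 nM as a true number. Compound 2 thus sits at the limit of > 36600 nM in this assay, at which 1 of the 2 values shown sits, and has no exact place in the series.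

Compound 3 (`COc1ccc(/C=C/[C@@](C)(/C=C/c2ccc(O)c(/C=C/C(=O)OC(C)(C)C)c2)CCC=C(C)C)cc1`) carries 2-(tert-butoxycarbonyl)ethenyl in place of 2-(ethoxycarbonyl)prop-1-en-1-yl on an aromatic carbon, ortho to a hydroxy group, with 2-(tert-butoxycarbonyl)ethenyl in place of 2-(ethoxycarbonyl)prop-1-en-1-yl on an aromatic carbon as the counted difference. Going by the values given here, the only measured step (an at least 3.7-fold higher number from compound 1 to compound 2 (0.57 log units; beyond the scatter)) brought in the group that now leaves, in place of formyl, so for compound 2 no change beyond the scatter is expected in this assay from this swap. The expected size is an at least 1.2-fold lower number from compound 2 to compound 3 (0.08 log units; that floor lies within the scatter) and stays within the scatter. For compound 3 the estimate is 30000 nM with 13000 nM to 70000 nM as the expected range.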

Compound 3, half-maximal effective concentration: > 36600 nM
Compound 3: a limit, no number; the forecaster's own chance of this, stated with the estimate: 50%; middle value at least 1.2-fold (0.08 log units) from the limit.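

In this assay compound 3 gives a limit and not a number, so the step from compound 2 cannot be read and the exchange of the two ester-bearing groups has no measurable size. The limit is now shared: the limit of > 36600 nM in this assay, at which 2 of the 3 values shown sit. Placing 2-(tert-butoxycarbonyl)ethenyl instead of formyl on this aromatic carbon, ortho to a hydroxy group, gives an at least 3.7-fold higher number from compound 1 to compound 3 (0.57 log units; beyond the scatter), so a second ester-bearing group, and not only 2-(ethoxycarbonyl)prop-1-en-1-yl, stands apart from formyl in this position.

As far as these compounds go, how far either ester-bearing compound lies past the limit stays open, and with it any order between them. Also open, from the compounds shown here alone, is how a carboxylic acid or a primary amide at this position would read, since either could show whether the ester itself matters.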